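A few compounds are considered here, and "the series" means these few. Any claim that something is new, unique, unknown or untested is made for them only; others in the source may bear on it.

Compound 1 `C=CCc1cc(C(C)=O)c(O)cc1OCC#N`: 2%
Compound 2 `C=CCc1cc(C(C)=O)c(O)cc1OCCCC#N`: 6%
Compound 3 `C=CCc1cc(C(C)=O)c(O)cc1OCCCCCC`: 9%

In an assay on isolated protein for binding affinity to leukotriene B4 receptor 1 (Homo sapiens), tested at 1 uM (on this read-out lower numbers stand for less inhibition and higher numbers for more inhibition at the one concentration tested (going by the name of the read-out)), compound 3 gives 9%, the highest of the three numbers shown, though its gaps to the other two lie within the scatter: a number 3 percentage points higher from compound 2 to compound 3 (within the scatter) and a number 7 percentage points higher from compound 1 to compound 3 (within the scatter). Compound 4 `C=CCc1cc(C(C)=O)c(O)cc1OCCCCCC(C)=O` differs from compound 3 by acetyl in place of methyl on a saturated chain carbon, five bonds along the chain from an oxygen on an aromatic ring. Going by the values given here, no measured step alters the far end of the chain in this way; the steps that exist, a number 4 percentage points higher from compound 1 to compound 2 (within the scatter), a number 7 percentage points higher from compound 1 to compound 3 (within the scatter) and a number 3 percentage points higher from compound 2 to compound 3 (within the scatter), all rework the chain on the oxygen and all stay within the scatter. Compound 4 is therefore expected to show no step beyond the scatter in this assay, no change at the digits printed from compound 3 to compound 4 (within the scatter). The estimate for compound 4 is 9%, with a range from 0% to 20%.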

Compound 4, a percentage reported as inhibition, at one concentration (the size of the read-out at that concentration, not a potency): 58%
The estimate for compound 4 lay 49 percentage points below the measured number, outside the stated range (above it).
By their numbers in this assay, from the lowest: compounds 1, 2 and 3 (each within the scatter of the next); then compound 4.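

In this assay, going by these compounds alone, the far end of the chain on the oxygen proves able to shift the read-out: acetyl in place of methyl at this position gives a number 49 percentage points higher from compound 3 to compound 4 (beyond the scatter) and is the first change here to go beyond the scatter. The two nitrile-ended chains show the same gap, with a number 52 percentage points higher from compound 2 to compound 4 (beyond the scatter) and a number 56 percentage points higher from compound 1 to compound 4 (beyond the scatter), while the steps among compounds 1, 2 and 3 all stayed within the scatter. No evidence is given that accounts for this result.

The compounds shown leave open whether the ketone carbonyl itself or the added chain length carries the step. A terminal alcohol, amine or carboxylic acid, or the acetyl on a shorter or longer chain, would bear on that.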